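The source may report more compounds than this note shows. Statements on the series, on what has been measured and on what is new or still open speak of the compounds shown alone.

- compound 1 `COc1ccc(S(=O)(=O)Nc2ccc(-c3nc4cc(NS(=O)(=O)c5ccc(OC)cc5)ccc4o3)cc2)cc1`: 40000 nM
- compound 2 `COc1ccc(S(=O)(=O)Nc2ccc3oc(-c4ccc(NC(=O)c5ccc(Cl)s5)cc4)nc3c2)cc1`: 1900 nM
- compound 3 `COc1ccc(S(=O)(=O)Nc2ccc3oc(-c4ccc(NS(=O)(=O)c5cc(Br)ccc5OC)cc4)nc3c2)cc1`: 14000 nM

All three values come from a functional assay on HT-29 cells (Homo sapiens) for cytotoxicity, read by resazurin assay, with a stated time of 48 h; a higher number here means that more compound is needed for the effect, a lower number that less compound is needed. Compound 3 stands in the middle of the three, with a higher number than compound 2 and a lower number than compound 1.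

Compound 4 `COc1ccc(S(=O)(=O)Nc2ccc3oc(-c4ccc(NS(=O)(=O)c5cc(F)ccc5OC)cc4)nc3c2)cc1` differs from compound 3 in one place: fluoro in place of bromo on an aromatic carbon. This is fluoro in place of bromo on an aromatic carbon, para to a methoxy group, so 5-bromo-2-methoxyphenyl becomes 5-fluoro-2-methoxyphenyl.

Within the data shown here, no measured step swaps one halogen for another, so the evidence is indirect. The closest is a 2.9-fold lower number from compound 1 to compound 3 (0.46 log units; beyond the scatter), where 5-bromo-2-methoxyphenyl replaces 4-methoxyphenyl on a sulfonyl sulfur. That step brings in the bromo and also changes where the methoxy sits, and the data cannot separate the two. The larger steps, a 21-fold lower number from compound 1 to compound 2 (1.32 log units; beyond the scatter) and a 7.4-fold higher number from compound 2 to compound 3 (0.87 log units; beyond the scatter), replace the whole group on the nitrogen and say little about a single halogen.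

If the bromo accounts for part of the drop from compound 1, removing it should give back a little of that drop. A small move to a higher number is therefore expected, possibly no more than the scatter. The estimated change is a 1.4-fold higher number from compound 3 to compound 4 (0.15 log units; within the scatter). For compound 4 the expected value is 20000 nM, with an estimated range from 8000 nM to 45000 nM.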

Compound 4, half-maximal effective concentration: 15000 nM
For compound 4 the middle estimate is 1.3-fold (0.12 log units) above the measured one, within the range that was stated.
By their numbers in this assay, from the lowest: compound 2; then compounds 3 and 4 (each within the scatter of the next); then compound 1.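

In this assay, among these compounds, exchanging bromo for fluoro on this aromatic carbon, para to a methoxy group, gives a 1.1-fold higher number from compound 3 to compound 4 (0.03 log units; within the scatter), so the two halogens cannot be told apart here, although they differ in atom and this is the first direct halogen swap in the set. The step from the 4-methoxyphenyl group survives the exchange, with a 2.7-fold lower number from compound 1 to compound 4 (0.43 log units; beyond the scatter), which shows that this step does not need bromo specifically, while the gap to the chlorothiophene amide also stays in place, with a 7.9-fold higher number from compound 2 to compound 4 (0.90 log units; beyond the scatter), so the group as a whole on the nitrogen still counts for more among these compounds than the choice of halogen. No measurement offered here explains why the exchange leaves the number where it is.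

As far as these compounds go, whether a halogen is needed on this carbon at all stays open, as a plain hydrogen, an amine or a carboxylic acid in that place could give quite a different number or the same one. Also open, from the compounds shown here alone, is how much of the step from the 4-methoxyphenyl group comes from the changed place of the methoxy group rather than from the halogen.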